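Homologation at the Ring Carbon of Compound 2

The compounds below may be only part of what the source reports. "The series", "measured", "known", "first", "only" and "open" are said of these compounds alone.

In a functional assay on the whole organism (strain NMRI) with Mus musculus as the target, with a stated time of 5 min (on this read-out higher numbers stand for an effect only at larger amounts of compound and lower numbers for an effect already at smaller amounts), compound 2, `CCC1(CCCCN2CCN(c3cccc(Cl)c3)CC2)C(=O)Nc2ccccc21`, gives only a limit, > 10 mg/kg. Its neighbour compound 1, `O=C1Nc2ccccc2C1CCCCN1CCN(c2cccc(Cl)c2)CC1`, also gives only a limit, > 10 mg/kg. The step that the two limits leave unreadable from compound 1 to compound 2 therefore cannot be read, and both values sit at the limit of > 10 mg/kg in this assay, at which 2 of the 2 values shown sit. Compound 3, `CC(C)CC1(CCCCN2CCN(c3cccc(Cl)c3)CC2)C(=O)Nc2ccccc21`, differs by isopropyl in place of methyl on a saturated chain carbon bound to a saturated ring carbon. Among the measured compounds shown here, no measured step bears on this change in size or direction. Compound 3 is expected at 10 mg/kg, between 3 mg/kg and 30 mg/kg, most likely again a limit, so that a number no higher from compound 2 to compound 3 (the limit leaves the size open) is the expected step.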

Compound 3, minimum effective dose: > 10 mg/kg
Compound 3: only a limit was reported; the forecaster's own chance of this, stated with the estimate: 75%; the middle value lies on the limit itself.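

Compound 1, compound 2 and compound 3 each give only a limit in this assay, so no new step can be read among them: the limit of > 10 mg/kg in this assay, at which 3 of the 3 values shown sit. The compounds shown leave open whether the group on the saturated ring carbon affects the minimum effective dose at all.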